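A sulfonyl aryl exchange leading toward compound 3

This account rests on a few compounds, and the source may have more. Where it says the series, first, only, none or still open, it means among the compounds named here.

Compound 1 `COC(=O)c1cc(=O)c2c(OC)cc(OC)cc2n1S(=O)(=O)c1ccc(C)cc1` gives 6000 nM in a functional assay on KOPN-8 cells (Homo sapiens) for antiproliferative activity, with a stated time of 72 h; on this read-out higher numbers stand for an effect only at larger amounts of compound and lower numbers for an effect already at smaller amounts. Compound 2 `COc1ccc(-c2cc(=O)c3c(OC)cc(OC)cc3n2S(=O)(=O)c2cc(Cl)cc(Cl)c2O)cc1` reaches only a limit of the assay in this assay, namely > 37900 nM; this is the limit of > 37900 nM in this assay, at which 1 of the 2 values shown sits. Compound 3 `COc1ccc(-c2cc(=O)c3c(OC)cc(OC)cc3n2S(=O)(=O)c2ccc(C)cc2)cc1` carries 4-methylphenyl in place of 3,5-dichloro-2-hydroxyphenyl on a sulfonyl sulfur. Among the measured compounds shown here, no step between measured compounds is known here, so the direction of this change has to be estimated. Because compound 1, which bears the same 4-methylphenyl group, gives 6000 nM, the expected step of an at least 3.1-fold lower number from compound 2 to compound 3 (0.49 log units; beyond the scatter) is toward an effect at smaller amounts. The size of this expected step remains uncertain. Compound 3 is expected to give about 12000 nM, within 3000 nM to 40000 nM.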

Compound 3, half-maximal effective concentration: > 44800 nM
Compound 3 ended at the assay's limit (the forecaster's own chance of this, stated with the estimate: 35%); middle value at least 3.7-fold (0.57 log units) from the limit.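

Compound 3 also sits at a limit in this assay, so 4-methylphenyl on a sulfonyl sulfur does not by itself give a readable value: the limit of > 44800 nM in this assay, at which 1 of the 3 values shown sits. The step between the two limits cannot be read. The change that can be read is 4-methoxyphenyl in place of methoxycarbonyl on an aromatic carbon, with an at least 7.4-fold higher number from compound 1 to compound 3 (0.87 log units; beyond the scatter).

Going by these compounds, whether 3,5-dichloro-2-hydroxyphenyl on the sulfonyl sulfur differs from 4-methylphenyl at all stays open. So does how a carboxylic acid in place of methoxycarbonyl on that aromatic carbon would read in this assay.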